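Hydroxy in place of hydrogen on compound 3

The compounds below may be only part of what the source reports. "The series", "measured", "known", "first", "only" and "open" are said of these compounds alone.

Of the compounds shown here, three with a shared core have been measured so far in an ADME assay on cells (Hepatocyte, Homo sapiens) for metabolic stability, with a stated time of 30 min (a lower number here means that less of the compound is left, a higher number that more of the compound is left), as the test of how well they last. Compound 1 `CS(=O)(=O)NC1CCC(CN2CCN(c3cc(=O)c4cc(C(F)(F)F)cc([N+](=O)[O-])c4s3)CC2)CC1` carries a methanesulfonamido group on its saturated ring and gives 105% as its reading. Compound 2 `O=c1cc(N2CCN(CC3CCC(NS(=O)(=O)c4ccccc4)CC3)CC2)sc2c([N+](=O)[O-])cc(C(F)(F)F)cc12` carries a (phenylsulfonyl)amino group there and gives 90.8% as its reading. Compound 3 `O=c1cc(N2CCN(CC3CCCCC3)CC2)sc2c([N+](=O)[O-])cc(C(F)(F)F)cc12` has only hydrogen at that ring carbon and gives 82.4% as its reading. That leaves compound 3 clearly under compound 1 but level with compound 2 within the scatter.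

Compound 4 `O=c1cc(N2CCN(CC3CCC(O)CC3)CC2)sc2c([N+](=O)[O-])cc(C(F)(F)F)cc12` differs from compound 3 in one place: hydroxy in place of hydrogen on a saturated ring carbon (in words, hydroxy in place of hydrogen on a saturated ring carbon). Among the compounds with values here, two measured steps bear on this, each leaving hydrogen where a group stood: a number 22.6 percentage points lower from compound 1 to compound 3 (beyond the scatter) in one case and a number 8.4 percentage points lower from compound 2 to compound 3 (within the scatter) in the other. Neither removed group is a hydroxy, so they guide only loosely. Read in reverse, the steps from compound 1 and compound 2 suggest only a small upward move, none beyond the scatter. The expected step is a number 7.6 percentage points higher from compound 3 to compound 4 (within the scatter) on this reasoning. For compound 4 the estimated reading is 90% with an expected range from 75% to 105% in this assay's terms.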

Compound 4, percent of the compound remaining in the Hepatocyte assay: 72.7%
Beside the measured number, compound 4's estimate is 17.3 percentage points above it; the whole stated range lies above it.
By their numbers in the Hepatocyte assay, from the lowest: compounds 4, 3 and 2 (each within the scatter of the next, the first and the last beyond it); then compound 1.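

In the Hepatocyte assay the new result is a number 9.7 percentage points lower from compound 3 to compound 4 (within the scatter), so hydroxy stands level with hydrogen at this ring carbon. In the Hepatocyte assay the gap to the first sulfonamide compound is a number 18.1 percentage points lower from compound 2 to compound 4 (beyond the scatter). In the Hepatocyte assay the gap to the second sulfonamide compound is a number 32.3 percentage points lower from compound 1 to compound 4 (beyond the scatter). The earlier compounds shown here left open whether any group on this carbon would match them, and compound 4 shows that a group here does not in itself keep the reading high: what matters is which group it is, and a single hydroxy does not do what methanesulfonamido does in compound 1. In a physicochemical assay for solubility, read by HPLC, with a stated time of 20 min (on this read-out lower numbers stand for lower solubility and higher numbers for higher solubility), compound 3 gives < 0.1 ug/mL, which is a limit of the assay rather than a true number. In the physicochemical assay compound 4 gives 8.3 ug/mL. The change does show a clear effect on a different property, and the gain with hydroxy is recorded as: the measured solubility of compound 3, < 0.1 ug/mL, and of compound 4, 8.3 ug/mL, an at least 83-fold higher number (1.91 log units; beyond the scatter)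

As far as these compounds go, what stays open is whether one group at this ring carbon can combine the lasting power of compound 1 with the solubility of compound 4. An amine, a carboxylic acid or a methoxy group on the same carbon would test how far each reading depends on the group placed there.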